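Adding one methyl to compound 1

A few compounds are considered here, and "the series" means these few. Any claim that something is new, unique, unknown or untested is made for them only; others in the source may bear on it.

Measured so far in a physicochemical assay for lipophilicity, read by HPLC, measured as octanol-water partition (a higher number here means a more lipophilic compound, a lower number a more polar compound), are these compounds:
Compound 1 `C[Si](C)(C)c1ccc(O)cc1` gives 4.12
Compound 2 `CCC(CC)(CC)c1ccc(O)cc1` gives 5.03
Compound 3 `CC[Si](CC)(CC)c1ccc(O)cc1` gives 5.69

Compound 1 stands lowest of the three, and both compound 2 and compound 3 lie above it by more than the usual scatter. Compound 2 is the nearer of those two.

The compound still waiting for its number, compound 4 `CC[Si](C)(C)c1ccc(O)cc1`, keeps the core of compound 1 and carries one small change: methyl in place of hydrogen on a saturated chain carbon bound to a silicon atom. Put another way, one methyl becomes an ethyl.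

Among the compounds with values here, no two measured compounds differ in just one place, so the size of such a step cannot be read directly from these data. Compound 3 gives 5.69 against compound 1 at 4.12, and one added methyl is expected to cover only part of that gap. The step expected in this assay is therefore upward and modest, probably a little beyond the scatter. The estimate amounts to a number 0.53 log units higher from compound 1 to compound 4 (beyond the scatter) as an expected change. For compound 4 the expected value is 4.65 with an estimated range from 4.35 to 5 around it.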

Compound 4, partition coefficient: 4.64
Beside the measured number, compound 4's estimate is 0.01 log units above it; measured number inside the range.
By their numbers in this assay, from the lowest: compound 1; then compound 4; then compound 2; then compound 3.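

In this assay, putting a methyl in place of hydrogen on a saturated chain carbon bound to a silicon atom, which turns one methyl into an ethyl, gives a clean single-change reading: a number 0.52 log units higher from compound 1 to compound 4 (beyond the scatter). The earlier compounds shown here differed from one another in more than one place, so none of their pairs could isolate what this one added carbon does at this position. Within the data shown here, this pair now gives that missing measurement, although it is only one example of the change on one core, so it sets no general rule for the series.

No measurement shown here explains why the step has this size.

Going by these compounds, it remains open whether a longer chain such as propyl, a branched group such as isopropyl, or a polar group such as an amine or a carboxylic acid at this same place would move the number further, leave it about the same, or reverse the direction. Also open, on these data alone, is whether the methyl to ethyl change would give a similar step on a chain carbon bound to an ordinary carbon atom instead of a silicon atom.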